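Swapping the Anilino Group for Hydroxy in the Ketone Series

This account rests on a few compounds, and the source may have more. Where it says the series, first, only, none or still open, it means among the compounds named here.

Compound 1 `CCOCC1=CS(=O)(=O)c2ccccc2C1=O` gives 92.4% in a functional assay on the whole organism for inhibition, with Mus musculus as the target, at a dose of 10 mg/kg (a lower number here means less inhibition, a higher number more inhibition at the dose given (going by the name of the read-out)), whereas compound 2 `O=C1C(CNc2ccccc2)=CS(=O)(=O)c2ccccc21` gives 0%, the lower of the two numbers. Within the data shown here, the single change between them, a number 92.4 percentage points lower from compound 1 to compound 2 (beyond the scatter), shows how much this one place in the structure can shift the read-out. Compound 3 `O=C1C(CO)=CS(=O)(=O)c2ccccc21` differs from compound 2 by hydroxy in place of anilino on a saturated chain carbon bound to a double-bonded ring carbon. Among the measured compounds shown here, no measured step covers this exact exchange; the ethoxy-to-anilino step is the only pointer. Because compound 1 reaches 92.4% with ethoxy at the same place, compound 3 is expected to regain much of the inhibition, estimated at 60% within a range from 10% to 95%, an expected step of a number 60 percentage points higher from compound 2 to compound 3 (beyond the scatter).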

Compound 3, a percentage reported as inhibition, in the whole organism at one dose (the size of the read-out at that dose, not a potency): 99.3%
Compound 3: the middle estimate sits 39.3 percentage points below what was measured; measured number above the stated range.
By their numbers in this assay, from the lowest: compound 2; then compounds 1 and 3 (each within the scatter of the next).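

In this assay hydroxy in place of anilino gives a number 99.3 percentage points higher from compound 2 to compound 3 (beyond the scatter) at this saturated chain carbon, so the low reading of compound 2 goes with anilino and not with the shared core. Hydrogen in place of ethyl on the oxygen gives a number 6.9 percentage points higher from compound 1 to compound 3 (within the scatter) and does not separate hydroxy from ethoxy. Nothing available explains these readings. Open, as far as these compounds go, is whether a plain amine such as dimethylamino or a longer ether such as butoxy would read like anilino or like hydroxy, and whether the nitrogen or the aromatic ring of anilino goes with the loss.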